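The source may report more compounds than this note shows. Statements on the series, on what has been measured and on what is new or still open speak of the compounds shown alone.

Of the compounds shown here, three sharing one core have been measured in an ADME assay on S9 fraction from liver (Rattus norvegicus) for metabolic stability, read by LC-MS, using NADPH, with a stated time of 30 min; a lower number here means that less of the compound is left, a higher number that more of the compound is left. Compound 1 `CCCCCCCCc1ccc(OCC(=O)Cn2nnc(-c3ccccc3)n2)cc1` gives 33%, compound 2 `CCCCCCCCc1ccc(OCC(=O)Cn2nnc(-c3ccccc3Cl)n2)cc1` gives 28%, and compound 3 `CCCCCCCCc1ccc(OCC(=O)Cn2nnc(C(=O)O)n2)cc1` gives 52%, the highest of the three numbers and clear of both others beyond the scatter. Compound 4 `CCCCCCCCc1ccc(OCC(=O)Cn2nnc(-c3ccc(C(=O)O)cc3)n2)cc1` differs from compound 3 at one place: 4-carboxyphenyl in place of carboxy on an aromatic carbon. All three measured steps bear on this change. Two of them exchange an aromatic ring for carboxy, and both are modest: a number 19 percentage points higher from compound 1 to compound 3 (beyond the scatter), and a number 24 percentage points higher from compound 2 to compound 3 (beyond the scatter). The third, a number 5 percentage points lower from compound 1 to compound 2 (within the scatter), shows that chloro on that ring left the number within the scatter. Compound 4 keeps the carboxy of compound 3 but restores a ring like that of compound 1, so only part of the first of these steps is expected to reverse. A modest fall is therefore expected, with an estimated a number 11 percentage points lower from compound 3 to compound 4 (beyond the scatter). The estimated value in this assay for compound 4 is 41%, with an expected range from 27% to 55%.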

Compound 4, percent of the compound remaining: < 5%
Compound 4 ended at the assay's limit; the forecaster's own chance of this, stated with the estimate: 2%; at least 36 percentage points between middle value and limit.
By their numbers in this assay, from the lowest: compounds 2 and 1 (each within the scatter of the next); then compound 3. At a limit, below all of these: compound 4.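

In this assay compound 4 gives < 5%, which is a limit of the assay and not a number: the limit of < 5% in this assay, at which 1 of the 4 values shown sits. On this aromatic carbon of the five-membered aromatic ring with 4 nitrogen, 4-carboxyphenyl in place of carboxy gives a number at least 47 percentage points lower from compound 3 to compound 4 (beyond the scatter), so the higher number seen with carboxy at this place did not carry over once the carboxy stood on a phenyl ring. The ring itself proved sensitive to what it carries: carboxy in place of hydrogen gives a number at least 28 percentage points lower from compound 1 to compound 4 (beyond the scatter), and the comparison with the chloro compound gives a number at least 23 percentage points lower from compound 2 to compound 4 (beyond the scatter), whereas chloro in place of hydrogen gave only a number 5 percentage points lower from compound 1 to compound 2 (within the scatter).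

On these data alone, how far compound 4 lies past the limit stays open, so these steps give only minimum sizes. Also open, as far as these compounds go, is whether an amine or a methyl ester in place of carboxy on that ring would show the same fall.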